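Notes on a vinyl-to-(methoxymethoxy)methyl swap

This account rests on a few compounds, and the source may have more. Where it says the series, first, only, none or still open, it means among the compounds named here.

Measured so far:
compound 1 `C=CCn1c(-c2ccc(OC)cc2C=C)cc2ccccc2c1=O`: 22800 nM
compound 2 `COCOCc1cc(OC)c(OC)cc1-c1cc2ccccc2c(=O)[nH]1`: 73700 nM

Both were run in a functional assay on HCT-15 cells (Homo sapiens) for cytotoxicity, read by MTT assay, with a stated time of 48 h; on this read-out lower numbers stand for stronger inhibition and higher numbers for weaker inhibition. Compound 1 gives the lower of the two numbers; compound 2 gives the higher, and the gap lies beyond the scatter. Going by the values given here, the two differ in more than one place, so no single step is drawn between them. Compound 3 `C=CCn1c(-c2ccc(OC)cc2COCOC)cc2ccccc2c1=O` is not yet measured. It keeps compound 1 and changes one group: (methoxymethoxy)methyl in place of vinyl on an aromatic carbon. Among the compounds with values here, no step of this kind has been measured here. Compound 3 is expected to come out weaker than compound 1 by a small to moderate step, a 1.8-fold higher number from compound 1 to compound 3 (0.24 log units; within the scatter), possibly no further than the scatter. The estimate for compound 3 is 40000 nM, range 15000 nM to 100000 nM.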

Compound 3, half-maximal inhibitory concentration: 27800 nM
Compound 3: the middle estimate sits 1.4-fold (0.16 log units) above what was measured; measured number inside the range.
By their numbers in this assay, from the lowest: compounds 1 and 3 (each within the scatter of the next); then compound 2.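

In this assay the first step measured at this aromatic carbon, a 1.2-fold higher number from compound 1 to compound 3 (0.09 log units; within the scatter), exchanges vinyl for (methoxymethoxy)methyl. Going from 2 to 5 heavy atoms and adding 2 hydrogen-bond acceptors at this position therefore leaves compound 1 and compound 3 inseparable on this read-out. Nothing available bears on why this exchange reads as it does. Open, from the compounds shown here alone, is how an amine, a carboxylic acid or a longer chain would read on this carbon. Also open, going by these compounds, is whether the same exchange reads alike on the core of compound 2.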